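From difluoromethyl to cyclopropyl: estimating clearance in mouse microsomes

The source may report more compounds than this note shows. Statements on the series, on what has been measured and on what is new or still open speak of the compounds shown alone.

Compound 1 `O=C(O)Cn1nc(Cc2nc3cc(Cl)c(OCC(F)F)cc3[nH]2)c2ccccc2c1=O`: < 56.7 mL/min/kg
Compound 2 `COc1cc(OC)c(NC(=O)Cc2nn(CC(=O)O)c(=O)c3ccccc23)cc1Cl`: < 55 mL/min/kg

In an ADME assay on microsomes from liver (Mus musculus) for metabolic stability (on this read-out lower numbers stand for slow clearance and higher numbers for fast clearance), compound 1 gives < 56.7 mL/min/kg, which is a limit and not an exact number. Compound 2 gives < 55 mL/min/kg, which is also a limit. Compound 3 `O=C(O)Cn1nc(Cc2nc3cc(Cl)c(OCC4CC4)cc3[nH]2)c2ccccc2c1=O` keeps the core of compound 1 but has cyclopropyl in place of difluoromethyl on a saturated chain carbon bound to an oxygen on an aromatic ring. In other words, 2,2-difluoroethoxy becomes cyclopropylmethoxy. Among the compounds with values here, no measured pair of compounds shows what a single change does here, so this expectation is a cautious one. No step beyond the scatter is expected in this assay, and a further limit would be unsurprising. The estimated step runs a step that the limit leaves unreadable from compound 1 to compound 3. For compound 3 the estimated clearance is 45 mL/min/kg, with an expected range of 25 mL/min/kg to 85 mL/min/kg.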

Compound 3, clearance in the Mus musculus assay: 147 mL/min/kg
For compound 3 the middle estimate is 3.3-fold (0.51 log units) below the measured one; measured number above the stated range.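

In the Mus musculus assay compound 1 gives < 56.7 mL/min/kg, which is a limit. In the Mus musculus assay compound 2 gives < 55 mL/min/kg, which is also a limit. In the Mus musculus assay, replacing 2,2-difluoroethoxy with cyclopropylmethoxy on the shared core gives an at least 2.5-fold higher number from compound 1 to compound 3 (0.41 log units; beyond the scatter), so these limits gave no sign that this position could matter so much for clearance. In a physicochemical assay for solubility, measured as thermodynamic solubility, at pH 7.4 (a higher number here means a more soluble compound, a lower number a less soluble compound), compound 1 gives > 1000 ug/mL, which is a limit. In the physicochemical assay compound 3 gives 395 ug/mL. In the physicochemical assay, the same change gives an at least 2.5-fold lower number from compound 1 to compound 3 (0.40 log units; beyond the scatter), which means that one swap at this position moves both read-outs, towards faster clearance and lower solubility. Compound 1 has only a limit in each assay, so each step gives a smallest size and not an exact one: the limit of < 56.7 mL/min/kg in the Mus musculus assay, at which 1 of the 3 values shown sits.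

The compounds shown leave open whether the two steps follow from losing the fluorine atoms or from gaining the three-membered ring. An ethoxy group at the same place on the same core would help to separate these two parts of the change.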